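The source may report more compounds than this note shows. Statements on the series, on what has been measured and on what is new or still open speak of the compounds shown alone.

Compound 1 `CC(C)c1onc(-c2c(Cl)cccc2Cl)c1COc1ccc(-c2nc3ccc(C(=O)O)cc3n2CC(C)(C)C)cc1` carries a neopentyl group on the aromatic nitrogen of the shared core, and in an assay on Huh-7 cells for agonist activity at Bile acid receptor (Homo sapiens), read by a luciferase reporter (a lower number here means that less compound is needed, a higher number that more compound is needed for the effect), compound 1 gives 13 nM, the lowest of the three numbers measured. Compound 2 `CC(C)c1onc(-c2c(Cl)cccc2Cl)c1COc1ccc(-c2nc3ccc(C(=O)O)cc3n2-c2ccc(F)cc2)cc1` gives 32.2 nM and compound 3 `CC(=O)N1CCC(n2c(-c3ccc(OCc4c(-c5c(Cl)cccc5Cl)noc4C(C)C)cc3)nc3ccc(C(=O)O)cc32)CC1` gives 1430 nM. The step of a 2.5-fold higher number from compound 1 to compound 2 (0.39 log units; beyond the scatter) is modest, whereas a 110-fold higher number from compound 1 to compound 3 (2.04 log units; beyond the scatter) and a 44-fold higher number from compound 2 to compound 3 (1.65 log units; beyond the scatter) are large. Compound 4 `CC(C)c1onc(-c2c(Cl)cccc2Cl)c1COc1ccc(-c2nc3ccc(C(=O)O)cc3n2C2CCC2)cc1` differs from compound 1 only by cyclobutyl in place of neopentyl on an aromatic nitrogen. Both measured changes at this nitrogen raise the number; the large one brings in a group with a hydrogen-bond acceptor, while cyclobutyl, like neopentyl, carries none, so only a modest rise or none beyond the scatter is expected. Compound 4 is expected at 25 nM, with a range from 8 nM to 80 nM. That estimate corresponds to an expected step of a 1.9-fold higher number from compound 1 to compound 4 (0.28 log units; within the scatter).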

Compound 4, half-maximal effective concentration: 14.4 nM
Compound 4: middle estimate off by 1.7-fold (0.24 log units), on the high side; measured number inside the range.
By their numbers in this assay, from the lowest: compounds 1 and 4 (each within the scatter of the next); then compound 2; then compound 3.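

In this assay, cyclobutyl and neopentyl on the aromatic nitrogen cannot be told apart (a 1.1-fold higher number from compound 1 to compound 4 (0.04 log units; within the scatter)), so a four-membered carbon ring serves here as well as the open group. Cyclobutyl stands clear of both 4-fluorophenyl (a 2.2-fold lower number from compound 2 to compound 4 (0.35 log units; beyond the scatter)) and 1-acetylpiperidin-4-yl (a 99-fold lower number from compound 3 to compound 4 (2.00 log units; beyond the scatter)), so a ring on this nitrogen does not by itself raise the number. No evidence on the cause of these differences is at hand.

On these data alone, whether the large rise belongs to the acetyl group or to the piperidine ring stays open. As far as these compounds go, the response to a free piperidine amine or a longer alkyl chain on this nitrogen is also open.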